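This account rests on a few compounds, and the source may have more. Where it says the series, first, only, none or still open, it means among the compounds named here.

In a functional assay on HeLa cells (Homo sapiens) for inhibition (a higher number here means a weaker inhibitor, a lower number a stronger inhibitor), compound 1 (`Cc1cn(/C=C/C=O)c(=O)[nH]c1=O`) gives 23000 nM. Compound 3 (`Cc1cn(C)c(=O)n(/C=C/C=O)c1=O`) gives 10000 nM. Of these two numbers, compound 1 has the higher, which makes it the weaker inhibitor of the pair, and the gap between them lies beyond the scatter. Compound 2 (`Nc1ccn(/C=C/C=O)c(=O)n1`) gives only a limit of the assay, > 100000 nM, and so no exact number can be set beside the other two.

Going by the values given here, the next compound to be tested is compound 4 (`O=C/C=C/n1cc(F)c(=O)[nH]c1=O`), which has no measurement yet. It keeps the core of compound 1 but carries fluoro in place of methyl on an aromatic carbon, (fluoro in place of methyl on an aromatic carbon). Among the compounds with values here, none of the measured compounds shows this change on its own, so the expectation has little direct support. It is anchored on compound 1 and its value of 23000 nM, as the rest of the structure stays the same. In this assay, going by these compounds, the expected step of a 1.5-fold lower number from compound 1 to compound 4 (0.19 log units; within the scatter) is small, and no change beyond the scatter is expected, although a wide range has to stay open. For compound 4, the estimated value is 15000 nM, with an expected range from 5000 nM to 50000 nM.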

Compound 4, half-maximal inhibitory concentration: 60000 nM
The estimate for compound 4 lay 4.0-fold (0.60 log units) below the measured number; measured number above the stated range.
By their numbers in this assay, from the lowest: compound 3; then compound 1; then compound 4. At a limit, above all of these: compound 2.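

At the aromatic carbon that lies ortho to a group of 1 heavy atom and meta to a 2-formylethenyl group, the two groups do not read alike in this assay: fluoro in place of methyl gives a 2.6-fold higher number from compound 1 to compound 4 (0.42 log units; beyond the scatter). Going by these compounds alone, the earlier compounds offered no pair differing in one place, so this is the first single change that can be read, and it shows that this position responds to the swap, with methyl giving the stronger inhibitor of the two. The step is modest, and nothing shown gives a measured property that would account for it.

With only methyl and fluoro compared at this carbon, the compounds shown leave open how chloro, trifluoromethyl or a longer chain such as ethyl would read there, and so whether any trend runs across groups at this position. They also leave open whether fluoro in place of methyl would give a step of similar size on the structure of compound 3, which carries a further change elsewhere on the core.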